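A Chlorophenyl Variant on a Weakly Active Core

The compounds below may be only part of what the source reports. "The series", "measured", "known", "first", "only" and "open" are said of these compounds alone.

Compound 1, `COc1ccccc1NC1=CC(=O)c2nc3n(c2C1=O)[C@H]1OC[C@@H](O)[C@H]1OC3`, was tested in a functional assay on MCF7 cells (Homo sapiens) for inhibition, read by sulforhodamine B assay; a lower number here means a stronger inhibitor, a higher number a weaker inhibitor. In that assay compound 1 reached only the limit of > 4000 nM, so no number is known for it. Compound 2, `O=C1C(NCc2ccccc2)=CC(=O)c2c1nc1n2[C@H]2OC[C@@H](O)[C@H]2OC1`, likewise gave only a limit of > 8000 nM in this assay. Of the two values shown, compound 1 sits at one limit, as the limit of > 4000 nM in this assay, at which 1 of the 2 values shown sits, records. Compound 2 sits at the other, as the limit of > 8000 nM in this assay, at which 1 of the 2 values shown sits, records. Within the data shown here, no step between measured compounds can be read from these values. Compound 3, `O=C1C=C(Nc2cccc(Cl)c2)C(=O)c2c1nc1n2[C@H]2OC[C@@H](O)[C@H]2OC1`, differs from compound 1 in one place: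

3-chlorophenyl in place of 2-methoxyphenyl on an amine nitrogen

With both known values at limits, compound 3 is expected to show at best a small shift, a step that the limit leaves unreadable from compound 1 to compound 3, and most likely none beyond the scatter. Compound 3 is estimated at 6000 nM, within 2000 nM to 20000 nM, with a limit again quite likely.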

Compound 3, half-maximal inhibitory concentration: 4720 nM
The estimate for compound 3 lay 1.3-fold (0.10 log units) above the measured number; the range from low to high includes it.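

Among these compounds, compound 1 has only a limit in this assay, and no step from it to compound 3 can be read. The compounds shown leave open how far 3-chlorophenyl in place of 2-methoxyphenyl on the amine nitrogen shifts inhibition, if at all.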